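The source may hold more compounds than are shown below. What is called first, only, known or untested is meant among the compounds shown, and "the series" means these compounds.

Compound 1 `CC1(/C=C/c2ccc(F)cc2)C=CC(=O)O1`: 46500 nM
Compound 2 `COc1ccc(/C=C/C2(C)C=CC(=O)O2)cc1OC`: 176000 nM

In a functional assay on PC-3 cells (Homo sapiens) for inhibition, read by sulforhodamine B assay, with a stated time of 48 h (on this read-out lower numbers stand for stronger inhibition of growth and higher numbers for weaker inhibition of growth), compound 2 gives 176000 nM, the higher of the two numbers. Compound 1, at 46500 nM, lies lower by more than the usual scatter. Compound 3 `COc1ccc(/C=C/C2(C)C=CC(=O)O2)cc1` differs from compound 2 by hydrogen in place of methoxy on an aromatic carbon. Among the measured compounds shown here, no measured pair shows this change alone, so the expectation is loose: a modest fall in the number in this assay, toward compound 1 at 46500 nM. The estimated change is a 1.9-fold lower number from compound 2 to compound 3 (0.27 log units; within the scatter). For compound 3, the expected value is 95000 nM, with an estimated range of 40000 nM to 200000 nM.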

Compound 3, concentration for total growth inhibition: 145000 nM
Compound 3: the middle estimate sits 1.5-fold (0.18 log units) below what was measured, within the range that was stated.
By their numbers in this assay, from the lowest: compound 1; then compounds 3 and 2 (each within the scatter of the next).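

In this assay, losing this methoxy group gives a 1.2-fold lower number from compound 2 to compound 3 (0.08 log units; within the scatter), so this aromatic carbon shows no clear effect of the change. The methoxy group that remains in compound 3 matters more: with methoxy in place of fluoro on an aromatic carbon, the data show a 3.1-fold higher number from compound 1 to compound 3 (0.49 log units; beyond the scatter). Nothing at hand explains either step.

Only hydrogen and methoxy are compared at the first carbon, and only fluoro and methoxy at the second. As far as these compounds go, how a hydroxy group, an amine or a chloro group would behave at either carbon remains open.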